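Swapping the aryl group of compound 3 for an aminoalkyl chain

The source may report more compounds than this note shows. Statements on the series, on what has been measured and on what is new or still open speak of the compounds shown alone.

In a functional assay on A549 cells (Homo sapiens) for inhibition, read by MTT assay, with a stated time of 72 h (a higher number here means a weaker inhibitor, a lower number a stronger inhibitor), compound 3 (`O=C(CCC(=O)OCCCCCCSc1ccc([N+](=O)[O-])c2nonc12)Nc1ccc(C(F)(F)F)cc1`) gives 4020 nM, the highest of the three numbers. Compound 1 (`O=C(CCC(=O)OCCCCCCSc1ccc([N+](=O)[O-])c2nonc12)Nc1ccccc1`) gives 1960 nM and compound 2 (`COc1ccccc1NC(=O)CCC(=O)OCCCCCCSc1ccc([N+](=O)[O-])c2nonc12`) gives 1870 nM. Compound 4 (`CN(C)CCCNC(=O)CCC(=O)OCCCCCCSc1ccc([N+](=O)[O-])c2nonc12`) has 3-(dimethylamino)propyl in place of 4-(trifluoromethyl)phenyl on an amide-type nitrogen. The measured steps are small: a 1.0-fold lower number from compound 1 to compound 2 (0.02 log units; within the scatter), a 2.1-fold higher number from compound 1 to compound 3 (0.31 log units; beyond the scatter) and a 2.1-fold higher number from compound 2 to compound 3 (0.33 log units; beyond the scatter). Going by the values given here, all of them keep an aromatic ring on that nitrogen, so they bear on this change only loosely, and no measured compound lacks that ring. A similarly modest move towards a lower number is expected, estimated as a 2.1-fold lower number from compound 3 to compound 4 (0.33 log units; beyond the scatter). For compound 4 the estimate is 1900 nM, with an expected range of 600 nM to 6000 nM.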

Compound 4, half-maximal inhibitory concentration: 1580 nM
For compound 4 the middle estimate is 1.2-fold (0.08 log units) above the measured one; the measured number falls inside the stated range.
By their numbers in this assay, from the lowest: compounds 4, 2 and 1 (each within the scatter of the next); then compound 3.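

Compound 4 shows that the amide-type nitrogen does not need an aromatic ring to hold its number in this assay: with 3-(dimethylamino)propyl in place of 4-(trifluoromethyl)phenyl, the result is a 2.5-fold lower number from compound 3 to compound 4 (0.41 log units; beyond the scatter). The chain without a ring also sits level with the other two aryl groups, at a 1.2-fold lower number from compound 2 to compound 4 (0.07 log units; within the scatter) and a 1.2-fold lower number from compound 1 to compound 4 (0.09 log units; within the scatter). No measured evidence accounts for these results.

The compounds shown leave open whether the dimethylamino group itself matters or any chain would serve. A plain alkyl chain, a longer aminoalkyl chain or a carboxylic acid on that nitrogen would bear on this.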